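The source may hold more compounds than are shown below. What is called first, only, known or untested is meant among the compounds shown, and "the series" means these compounds.

Compound 3 `O=C(Nc1cccc(-c2oc3cc(-c4ccc(F)cc4)ccc3c(=O)c2O)c1)c1ccc(C(F)(F)F)cc1` gives 19400 nM in a functional assay on A549 cells (Homo sapiens) for antiproliferative activity, read by CCK-8 assay, with a stated time of 72 h (on this read-out lower numbers stand for stronger inhibition and higher numbers for weaker inhibition), the highest of the three measured amides; compound 1 `O=C(Nc1cccc(-c2oc3cc(-c4ccc(F)cc4)ccc3c(=O)c2O)c1)c1ccccc1F` gives 4410 nM and compound 2 `COc1ccc(C(=O)Nc2cccc(-c3oc4cc(-c5ccc(F)cc5)ccc4c(=O)c3O)c2)cc1` gives 8700 nM. Compound 4 `Cc1cccc(C(=O)Nc2cccc(-c3oc4cc(-c5ccc(F)cc5)ccc4c(=O)c3O)c2)c1` differs from compound 3 by 3-methylphenyl in place of 4-(trifluoromethyl)phenyl on a carbonyl carbon. For the measured compounds named here, two measured steps bear on this change: a 4.4-fold higher number from compound 1 to compound 3 (0.64 log units; beyond the scatter) and a 2.2-fold higher number from compound 2 to compound 3 (0.35 log units; beyond the scatter), both running toward higher numbers as the trifluoromethyl-bearing aryl enters. Taking it out again in compound 4 is therefore expected to bring a modest step toward a lower number in this assay, putting the 3-methylphenyl amide in the region of compound 1 and compound 2 rather than of compound 3. Compound 4 is estimated at 6500 nM, range 2500 nM to 16000 nM. The expected step is a 3.0-fold lower number from compound 3 to compound 4 (0.47 log units; beyond the scatter).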

Compound 4, half-maximal inhibitory concentration: 16500 nM
Estimate against measurement, compound 4: 2.5-fold (0.40 log units) below; measured number outside the range, above it.
By their numbers in this assay, from the lowest: compounds 1, 2, 4 and 3 (each within the scatter of the next, the first and the last beyond it).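

In this assay, 3-methylphenyl in place of 4-(trifluoromethyl)phenyl on the carbonyl carbon gives a step within the scatter (a 1.2-fold lower number from compound 3 to compound 4 (0.07 log units; within the scatter)), so a high number here does not require the trifluoromethyl group. The step to the 4-methoxyphenyl amide is also within the scatter (a 1.9-fold higher number from compound 2 to compound 4 (0.28 log units; within the scatter)), whereas the 2-fluorophenyl amide stands clearly apart (a 3.7-fold higher number from compound 1 to compound 4 (0.57 log units; beyond the scatter)). No available data explain these differences. On these data alone, whether the lower number of compound 1 depends on the fluorine itself remains open, as does the outcome with an amine or a carboxylic acid on this aryl ring.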